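The compounds below may be only part of what the source reports. "The series", "measured", "known", "first", "only" and "open" are said of these compounds alone.

Measured compounds:
Compound 1 `Nc1nc(O)c2c(n1)n(C1OC(CO)[C@@H](O)[C@H]1O)c(=O)n2C/C=C/c1ccccc1` gives 5% in a functional assay on the whole organism with Mus musculus as the target; a lower number here means a smaller maximal response, a higher number a larger maximal response.
Compound 2 `CN(C)CCCn1c(=O)n(C2OC(CO)[C@@H](O)[C@H]2O)c2nc(N)nc(O)c21` gives 63%.
Compound 3 `CCCCCCn1c(=O)n(C2OC(CO)[C@@H](O)[C@H]2O)c2nc(N)nc(O)c21` gives 11%.

Compound 3 stands second highest of the three numbers. Its nearest neighbour is compound 1, a number 6 percentage points higher from compound 1 to compound 3 (within the scatter), a gap within the scatter; its furthest is compound 2, a number 52 percentage points lower from compound 2 to compound 3 (beyond the scatter). Compound 4 `Nc1nc(O)c2c(n1)n(C1OC(CO)[C@@H](O)[C@H]1O)c(=O)n2Cc1ccc([N+](=O)[O-])cc1` is the next step from compound 3: 4-nitrophenyl in place of pentyl on a saturated chain carbon bound to an aromatic nitrogen.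

For the measured compounds named here, two measured steps bear on this change. The step of a number 6 percentage points higher from compound 1 to compound 3 (within the scatter) shows that a pentyl and a 2-phenylethenyl on that carbon give numbers within the scatter of each other, so a group with a six-membered aromatic ring at this place has not raised the response. The large step of a number 58 percentage points higher from compound 1 to compound 2 (beyond the scatter) went with a dimethylamino group entering, and a number 52 percentage points lower from compound 2 to compound 3 (beyond the scatter) fell when that group left; compound 4 carries no such group. The author therefore expects no step beyond the scatter, a number 1 percentage points lower from compound 3 to compound 4 (within the scatter). Compound 4 is estimated at 10%, within 2% to 30%.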

Compound 4, largest response reached (reported as maximal response), in percent of the reference or control that the assay uses: 16%
The estimate for compound 4 lay 6 percentage points below the measured number, within the range that was stated.
By their numbers in this assay, from the lowest: compounds 1, 3 and 4 (each within the scatter of the next, the first and the last beyond it); then compound 2.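

In this assay, 4-nitrophenyl in place of pentyl gives a number 5 percentage points higher from compound 3 to compound 4 (within the scatter), so these two groups cannot be told apart at this place, although the entering group has a six-membered aromatic ring and a nitro group. For the compounds shown here, in place of 2-phenylethenyl, the same group gives a modest step, a number 11 percentage points higher from compound 1 to compound 4 (beyond the scatter), the first step beyond the scatter at this place that involves no dimethylamino group. The step of a number 47 percentage points lower from compound 2 to compound 4 (beyond the scatter) leaves compound 2 alone with a large response among the four compounds, and none of them goes against the link between that response and the dimethylamino group.

From the compounds shown here alone, it remains open whether a primary amine or a carboxylic acid at the chain end would give a response like that of compound 2. Going by these compounds, it is also open whether a longer chain would carry the dimethylamino group as well, or whether plain benzyl would match 4-nitrobenzyl. No measurement here explains any of these differences.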